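The source may report more compounds than this note shows. Statements on the series, on what has been measured and on what is new or still open speak of the compounds shown alone.

Measured in an ADME assay on LLC-MK2 cells (Macaca mulatta) for cytotoxicity, read by spectrophotometry and crystal violet staining, with a stated time of 4 days; on this read-out lower numbers stand for higher toxicity in this test and higher numbers for lower toxicity in this test:
- Compound 1 `CC(C)n1ncc2c(C(=O)Nc3ncccn3)cc(-c3cccs3)nc21`: 75000 nM
- Compound 2 `CC(C)n1ncc2c(C(=O)Nc3cccc(F)c3)cc(-c3cccs3)nc21`: > 200000 nM, a limit of the assay and not a number
- Compound 3 `CC(C)n1ncc2c(C(=O)N3CCc4cccnc43)cc(-c3cccs3)nc21`: 50000 nM

Two steps place the last of these. The step of a 1.5-fold lower number from compound 1 to compound 3 (0.18 log units; within the scatter) does not separate it from the pyrimidin-2-yl relative, whereas an at least 4.0-fold lower number from compound 2 to compound 3 (0.60 log units; beyond the scatter) sets it clearly apart from the 3-fluorophenyl relative.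

Compound 4 `CC(C)n1ncc2c(C(=O)Nc3cncnc3)cc(-c3cccs3)nc21` comes next, with this change: a group of 7 heavy atoms (4 carbon, 3 nitrogen; one six-membered aromatic ring with 2 hetero atoms) in place of a group of 9 heavy atoms (7 carbon, 2 nitrogen; one five-membered non-aromatic ring with 1 hetero atom, one six-membered aromatic ring with 1 hetero atom), on a carbonyl carbon. The (pyrimidin-5-yl)amino group that enters on the carbonyl carbon resembles the pyrimidin-2-yl group of compound 1, since both carry the same kind of ring. The step of a 1.5-fold lower number from compound 1 to compound 3 (0.18 log units; within the scatter) is therefore the closest guide, and it suggests that this exchange matters little. The step of an at least 2.6-fold higher number from compound 1 to compound 2 (0.42 log units; beyond the scatter) shows that a change of aromatic ring can move the number upward, so a small upward lean seems reasonable.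

The expected step is a 1.4-fold higher number from compound 3 to compound 4 (0.15 log units; within the scatter), which would stay within the scatter. For compound 4 the estimated value is 70000 nM, with an expected range from 30000 nM to 180000 nM.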

Compound 4, half-maximal cytotoxic concentration: 20000 nM
Beside the measured number, compound 4's estimate is 3.5-fold (0.54 log units) above it, outside the stated range (below it).
By their numbers in this assay, from the lowest: compound 4; then compounds 3 and 1 (each within the scatter of the next). At a limit, above all of these: compound 2.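

In this assay, pyrimidin-5-yl and pyrimidin-2-yl carry the same kind of ring, yet exchanging them on the amide-type nitrogen gives a 3.8-fold lower number from compound 1 to compound 4 (0.57 log units; beyond the scatter), so the ring type alone does not set the number at this position. The change on the carbonyl carbon also gives a 2.5-fold lower number from compound 3 to compound 4 (0.40 log units; beyond the scatter), which makes this the lowest number of the four and the highest toxicity in this test. The step of an at least 10-fold lower number from compound 2 to compound 4 (1.00 log units; beyond the scatter) rests on a limit and not a number, so its full size is unknown: the limit of > 200000 nM in this assay, at which 1 of the 4 values shown sits.

The compounds shown leave open where a pyridin-3-yl or plain phenyl group on the amide-type nitrogen would fall, and so whether this low number is particular to pyrimidin-5-yl. Going by these compounds, all four also share the rest of the core, so the effect of changes there remains open.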